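From compound 1 to compound 4: one sulfonyl group changes

This account rests on a few compounds, and the source may have more. Where it says the series, first, only, none or still open, it means among the compounds named here.

In an ADME assay on FHC cells (Homo sapiens) for cytotoxicity, read by resazurin assay, with a stated time of 48 h (a lower number here means that less compound is tolerated, a higher number that more compound is tolerated), compound 1 `COc1ccc(S(=O)(=O)Nc2ccc(-c3nc4cc(NS(=O)(=O)c5ccc(OC)cc5)ccc4o3)cc2)cc1` gives 57000 nM. Two relatives have also been measured: compound 2 `O=S(=O)(Nc1ccc(-c2nc3cc(NS(=O)(=O)c4ccccc4Cl)ccc3o2)cc1)c1ccccc1Cl` gives 45000 nM, and compound 3 `O=S(=O)(Nc1ccc(-c2nc3cc(NS(=O)(=O)c4ccc(Cl)s4)ccc3o2)cc1)c1ccc(Cl)c(C(F)(F)F)c1` gives 63000 nM. All three numbers lie within the usual scatter of one another, so compound 1 stands level with both of the others and the data show no ranking among them.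

Compound 4 `COc1ccc(S(=O)(=O)Nc2ccc3oc(-c4ccc(NS(=O)(=O)c5cc(Br)ccc5OC)cc4)nc3c2)cc1` has not yet been measured. It differs from compound 1 in one place: 5-bromo-2-methoxyphenyl in place of 4-methoxyphenyl on a sulfonyl sulfur. On a sulfonyl sulfur, 5-bromo-2-methoxyphenyl stands in place of 4-methoxyphenyl, and the rest of the structure stays the same.

Among the compounds with values here, no measured pair of compounds shows this exact change, so any forecast must lean on indirect evidence. Compound 2, at 45000 nM, and compound 3, at 63000 nM, carry other groups on their sulfonyl sulfurs, yet neither separates from compound 1 in this assay. On that limited evidence, no change beyond the scatter is expected. The estimated step is small, a 1.1-fold lower number from compound 1 to compound 4 (0.06 log units; within the scatter), and lies within the scatter. For compound 4 the expected value is 50000 nM, with an estimated range from 25000 nM to 100000 nM.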

Compound 4, half-maximal cytotoxic concentration: > 100000 nM
Compound 4 gave a limit, no number (the forecaster's own chance of this, stated with the estimate: 15%); middle value at least 2.0-fold (0.30 log units) from the limit.
By their numbers in this assay, from the lowest: compounds 2, 1 and 3 (each within the scatter of the next). At a limit, above all of these: compound 4.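

Compound 1 and compound 4 form the first pair shown that differs in only one place, so this sulfonyl group can be read on its own, without the other changes that compound 2 and compound 3 carry. In this assay compound 4 stops at a limit of the assay, so its result is not an exact number: the limit of > 100000 nM in this assay, at which 1 of the 4 values shown sits. Placing 5-bromo-2-methoxyphenyl in place of 4-methoxyphenyl on a sulfonyl sulfur gives an at least 1.7-fold higher number from compound 1 to compound 4 (0.24 log units; that floor lies within the scatter), so this position accepts the larger group with no fall in the tolerated concentration, although the floor alone does not separate the two compounds and the true gap could be larger.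

The bromine and the new place of the methoxy group enter together here, and the compounds shown do not tell their contributions apart. Also open, as far as these compounds go, is how this position would respond to a phenyl ring carrying an amine or a carboxylic acid, or to a plain methyl group on the sulfonyl sulfur in place of the ring.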